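Solubility notes on the piperidine amide series

A few compounds are considered here, and "the series" means these few. Any claim that something is new, unique, unknown or untested is made for them only; others in the source may bear on it.

Measured compounds:
compound 1, `NC(=O)CC1CCN(c2nc(-c3cc(F)c(Cl)cc3F)nc3c2CS(=O)(=O)C3)CC1`, 15000 nM
compound 2, `CNC(=O)C1CCN(c2nc(-c3cc(F)c(Cl)cc3F)nc3c2CS(=O)(=O)C3)CC1`, 11000 nM
compound 3, `NC(=O)CN1CCN(c2nc(-c3cc(F)c(Cl)cc3F)nc3c2CS(=O)(=O)C3)CC1`, which in a physicochemical assay for solubility, with a stated time of 20 h, at pH 6.8 (a lower number here means a less soluble compound, a higher number a more soluble compound), reaches only the assay limit, > 100000 nM

Compound 1 holds the highest number among the two plain values; compound 2 sits nearest, with a 1.4-fold lower number from compound 1 to compound 2 (0.13 log units; within the scatter). Compound 3 is reported as a limit of > 100000 nM in this assay, at which 1 of the 3 values shown sits, and gives an at least 6.6-fold higher number from compound 1 to compound 3 (0.82 log units; beyond the scatter) and an at least 9.0-fold higher number from compound 2 to compound 3 (0.95 log units; beyond the scatter).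

Compound 4, `O=S1(=O)Cc2nc(-c3cc(F)c(Cl)cc3F)nc(N3CCC(CO)CC3)c2C1`, is not yet measured. It differs from compound 1 as follows: hydroxy in place of carbamoyl on a saturated chain carbon bound to a saturated ring carbon. The measured steps offer only indirect guidance. The step from compound 1 to compound 2 alters the substituent on the saturated ring carbon and stays within the scatter; the steps to compound 3 swap the piperidine for a piperazine on the aromatic carbon and run beyond the scatter, but do not touch a carbamoyl. Going by the values given here, no measured step removes the carbamoyl for a hydroxy. On this basis the change for compound 4 is expected to stay within the scatter, no change at the digits printed from compound 1 to compound 4 (within the scatter). Compound 4 is therefore estimated at 15000 nM, with a range from 5000 nM to 45000 nM.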

Compound 4, solubility: 16000 nM
For compound 4 the middle estimate is 1.1-fold (0.03 log units) below the measured one; measured number inside the range.
By their numbers in this assay, from the lowest: compounds 2, 1 and 4 (each within the scatter of the next). At a limit, above all of these: compound 3.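

In this assay, the carbamoyl on a saturated chain carbon bound to a saturated ring carbon can be replaced by hydroxy with no readable change, giving a 1.1-fold higher number from compound 1 to compound 4 (0.03 log units; within the scatter), and hydroxymethyl in place of methylcarbamoyl on a saturated ring carbon gives a 1.5-fold higher number from compound 2 to compound 4 (0.16 log units; within the scatter). The amide is therefore not needed at this position to hold the number seen for the piperidine compounds, yet 4-(hydroxymethyl)piperidin-1-yl does not close the gap to the piperazine, with an at least 6.2-fold lower number from compound 3 to compound 4 (0.79 log units; beyond the scatter). The value of compound 3 is a limit, not a number: the limit of > 100000 nM in this assay, at which 1 of the 4 values shown sits.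

Still open, on these data alone, is whether a primary amine, a carboxylic acid or a longer chain ending in hydroxy at this place would move the number beyond the scatter. As far as these compounds go, how far compound 3 truly lies from the other compounds also stays open.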